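This account rests on a few compounds, and the source may have more. Where it says the series, first, only, none or still open, it means among the compounds named here.

The three compounds with a result share one core. Compound 1 `O=S(=O)(NCCCNc1nccc(-c2c(-c3cccc(F)c3)nc3sccn23)n1)c1cccc(F)c1` bears a (((3-fluorophenyl)sulfonyl)amino)methyl group on a saturated chain carbon, and in a functional assay on SK-MEL-28 cells (Homo sapiens) for cytotoxicity, read by MTT assay (on this read-out lower numbers stand for stronger inhibition and higher numbers for weaker inhibition), compound 1 gives 8550 nM. Compound 2 `Cc1ccc(S(=O)(=O)NCCNc2nccc(-c3c(-c4cccc(F)c4)nc4sccn34)n2)cc1` carries a ((4-methylphenyl)sulfonyl)amino group in its place; in this assay compound 2 reaches only a limit, > 20000 nM. Compound 3 `O=C(NCCNc1nccc(-c2c(-c3cccc(F)c3)nc3sccn23)n1)c1ccc(C(F)(F)F)cc1` has a (4-(trifluoromethyl)phenyl)carbonyl group on the amine nitrogen, and in this assay compound 3 gives 9260 nM. Within the data shown here, the numbers of compound 3 and compound 1 lie within the scatter of each other, and the only other value in this assay is a limit (the limit of > 20000 nM in this assay, at which 1 of the 3 values shown sits).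

The change to compound 4 `O=S(=O)(NCCNc1nccc(-c2c(-c3cccc(F)c3)nc3sccn23)n1)c1ccccc1` is phenylsulfonyl in place of (4-(trifluoromethyl)phenyl)carbonyl on an amine nitrogen. Among the measured compounds shown here, two measured steps bear on it: an at least 2.3-fold higher number from compound 1 to compound 2 (0.36 log units; beyond the scatter), and an at least 2.1-fold lower number from compound 2 to compound 3 (0.33 log units; beyond the scatter). Together they show the sulfonyl amide of compound 2 at the weak end of these compounds, while compound 1, also a sulfonyl amide, gives a plain number. Compound 4 resembles compound 2 most closely, so a weaker result than compound 3 is expected, a step of about a 1.9-fold higher number from compound 3 to compound 4 (0.29 log units; within the scatter). The estimate for compound 4 is 18000 nM, between 8000 nM and 40000 nM, with a fair chance that only a limit is reported.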

Compound 4, half-maximal inhibitory concentration: 19000 nM
The estimate for compound 4 lay 1.1-fold (0.02 log units) below the measured number; the measured number falls inside the stated range.
By their numbers in this assay, from the lowest: compounds 1 and 3 (each within the scatter of the next); then compound 4. At a limit, above all of these: compound 2.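

Among these compounds, compound 4 gives the first plain number for a sulfonyl group on the amine nitrogen of the shorter chain that compound 2 and compound 3 share, and in this assay phenylsulfonyl in place of (4-(trifluoromethyl)phenyl)carbonyl gives a 2.1-fold higher number from compound 3 to compound 4 (0.31 log units; beyond the scatter). Compound 1 stays apart from this sulfonyl amide, with a 2.2-fold higher number from compound 1 to compound 4 (0.35 log units; beyond the scatter), but that single step alters both the chain and the fluorine on the phenyl ring, so it does not assign the difference to either. Hydrogen in place of methyl on an aromatic carbon gives an at least 1.0-fold lower number from compound 2 to compound 4 (0.02 log units; that floor lies within the scatter), and this step cannot be read as a real change because compound 2 stands only at a limit: the limit of > 20000 nM in this assay, at which 1 of the 4 values shown sits.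

The compounds shown leave open whether the longer chain of compound 1 or its fluorine carries the step to compound 4, since no pair here changes one of them alone. They also leave open how an amine or a carboxylic acid on the phenyl ring would read in this assay, and whether a carbonyl and a sulfonyl group would differ in the same way on the longer chain.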